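Thiourea to Urea on the Ring Nitrogen

The source may hold more compounds than are shown below. What is called first, only, known or untested is meant among the compounds shown, and "the series" means these compounds.

Measured so far:
compound 1 `NC(=O)c1c(NC(=O)c2cccc([N+](=O)[O-])c2)sc2c1CCN(Cc1ccc(Cl)cc1Cl)C2` — 19800 nM
compound 2 `NC(=O)c1c(NC(=O)c2cccc([N+](=O)[O-])c2)sc2c1CCN(C(=S)Nc1ccccc1Cl)C2` — 7040 nM

In a functional assay on HL-60 cells (Homo sapiens) for antiproliferative activity, with a stated time of 24 h (a lower number here means a stronger inhibitor, a higher number a weaker inhibitor), compound 1 gives 19800 nM and compound 2 gives 7040 nM. Going by the values given here, the one step between them is a 2.8-fold lower number from compound 1 to compound 2 (0.45 log units; beyond the scatter). Among the compounds with values here, on the two numbers at hand, compound 2 therefore stands lowest, and its only neighbour is compound 1.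

Compound 3 `NC(=O)c1c(NC(=O)c2cccc([N+](=O)[O-])c2)sc2c1CCN(C(=O)Nc1ccccc1Cl)C2` keeps the shared core and differs from compound 2 by a group of 10 heavy atoms (7 carbon, 1 nitrogen, 1 oxygen, 1 chlorine; one six-membered aromatic ring of carbon only) in place of a group of 10 heavy atoms (7 carbon, 1 nitrogen, 1 sulfur, 1 chlorine; one six-membered aromatic ring of carbon only), on an amine nitrogen in a ring. Within the data shown here, none of the measured steps bears directly on this exchange: the only step known, a 2.8-fold lower number from compound 1 to compound 2 (0.45 log units; beyond the scatter), replaced a different group on the same ring nitrogen and says nothing about swapping the thiourea of compound 2 for the (2-chlorophenyl)carbamoyl group of compound 3. Among the measured compounds shown here, with no guiding step, the expectation is of no change beyond the scatter, with a broad range to either side. Compound 3 is thus expected to give about 9000 nM in this assay, most likely between 3000 nM and 27000 nM. The expected step is a 1.3-fold higher number from compound 2 to compound 3 (0.11 log units; within the scatter).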

Compound 3, half-maximal inhibitory concentration: 18500 nM
Estimate against measurement, compound 3: 2.1-fold (0.31 log units) below, and the stated range covers the measured number.
By their numbers in this assay, from the lowest: compound 2; then compounds 3 and 1 (each within the scatter of the next).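

The thiourea and urea pair isolates the exchange of sulfur for oxygen, with the rest of the group on the ring nitrogen unchanged, and in this assay that exchange gives a 2.6-fold higher number from compound 2 to compound 3 (0.42 log units; beyond the scatter), so this position responds to that change alone. A second comparison shows that (2-chlorophenyl)carbamoyl in place of 2,4-dichlorobenzyl gives a 1.1-fold lower number from compound 1 to compound 3 (0.03 log units; within the scatter), which places these two quite different groups level and means that, among these three compounds, only the thiourea of compound 2 stands apart from the others. Nothing available explains why sulfur and oxygen differ here.

Going by these compounds, it remains open whether the thiourea would keep its advantage over the urea with another substituent on its nitrogen, such as a methyl group, an unsubstituted phenyl ring or a longer alkyl chain in place of the 2-chlorophenyl ring. Also open, on these data alone, is whether a guanidine or a simple acetyl group on the same ring nitrogen would read with compound 2 or with compound 3.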